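Chloro to hydrogen on the benzoyl arm of compound 1

The source may report more compounds than this note shows. Statements on the series, on what has been measured and on what is new or still open speak of the compounds shown alone.

Among the measured compounds shown here, compound 1 `O=C(Nc1cc(C(F)(F)F)cc(C(F)(F)F)c1)C1CCc2ccccc2N1C(=O)c1ccccc1Cl` stands as the stronger of the two measured members. In a functional assay on PC-3 cells (Homo sapiens) for cytotoxicity, read by sulforhodamine B assay, with a stated time of 72 h (a lower number here means a stronger inhibitor of growth, a higher number a weaker inhibitor of growth), compound 1 gives 8040 nM, the lowest of the two numbers in hand. Compound 2 `COc1ccc(NC(=O)C2CCc3ccccc3N2)cc1` gives 56900 nM in this assay; the gap to compound 1 lies beyond the usual scatter, but the two structures differ in more than one place, so no single step can be read from them. Compound 3 `O=C(Nc1cc(C(F)(F)F)cc(C(F)(F)F)c1)C1CCc2ccccc2N1C(=O)c1ccccc1` is the next compound to be measured. It differs from compound 1 by hydrogen in place of chloro on an aromatic carbon. For the measured compounds named here, no measured pair isolates such a change here, so the direction is open; with only one heavy atom leaving, the expected step of a 1.4-fold higher number from compound 1 to compound 3 (0.14 log units; within the scatter) is small and within the scatter, a slight weakening being held possible. Compound 3 is therefore expected to give 11000 nM in this assay, estimated within 4000 nM to 30000 nM.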

Compound 3, concentration for 50% growth inhibition: 3500 nM
The estimate for compound 3 lay 3.1-fold (0.50 log units) above the measured number, outside the stated range (below it).
By their numbers in this assay, from the lowest: compound 3; then compound 1; then compound 2.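

Going from 2-chlorophenyl to phenyl on the benzoyl arm gives the first step in the series that can be read at a single place, with a 2.3-fold lower number from compound 1 to compound 3 (0.36 log units; beyond the scatter) in this assay. The chloro on this aromatic carbon, ortho to a large group, is therefore not required for growth inhibition in this pair, and hydrogen gives the lower number. No measurement in hand bears on the reason for this gain.

As far as these compounds go, whether other groups at this carbon, such as an amine or a carboxylic acid, would lower the number further or raise it remains open, as does the effect of chloro elsewhere on this ring. Compound 2 differs from both other compounds in more than one place, so its steps cannot be read.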